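The compounds below may be only part of what the source reports. "The series", "measured", "known", "first", "only" and "open" are said of these compounds alone.

Going by the values given here, in a functional assay on KM12 cells (Homo sapiens) for antiproliferative activity (a higher number here means a weaker inhibitor of growth, a lower number a stronger inhibitor of growth), compound 1 `COc1ccc(-c2nc3cc(F)ccc3s2)cc1Br` gives 6700 nM and compound 2 `COc1ccc(-c2nc3cc(F)ccc3s2)cc1I` gives 6900 nM, so compound 2 stands level with its only measured neighbour. Compound 3 `CCOc1cc(-c2nc3cc(F)ccc3s2)ccc1OC` differs from compound 2 as follows: ethoxy in place of iodo on an aromatic carbon. Among the compounds with values here, the only measured step, a 1.0-fold higher number from compound 1 to compound 2 (0.01 log units; within the scatter), lies within the scatter, but it replaces bromo with iodo, so it says little about ethoxy in place of iodo. Within the data shown here, no measured step fixes the direction, so a clear move to a lower number is only a tentative expectation. The expected step is a 6.9-fold lower number from compound 2 to compound 3 (0.84 log units; beyond the scatter). The estimate for compound 3 is 1000 nM, with a range from 20 nM to 10000 nM.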

Compound 3, concentration for 50% growth inhibition: 5420 nM
The estimate for compound 3 lay 5.4-fold (0.73 log units) below the measured number; the measured number falls inside the stated range.
By their numbers in this assay, from the lowest: compounds 3, 1 and 2 (each within the scatter of the next).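

In this assay, ethoxy in place of iodo gives a 1.3-fold lower number from compound 2 to compound 3 (0.10 log units; within the scatter) and ethoxy in place of bromo gives a 1.2-fold lower number from compound 1 to compound 3 (0.09 log units; within the scatter), and both steps lie within the scatter. The earlier pair compared only two halogens, whereas this result shows that an ethoxy group, with its oxygen and three heavy atoms, also reads level with them at this position, ortho to a methoxy group. No supporting measurement bears on why these groups read alike. From the compounds shown here alone, what an amine, a carboxylic acid or a longer chain would do here remains open.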